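A few compounds are considered here, and "the series" means these few. Any claim that something is new, unique, unknown or untested is made for them only; others in the source may bear on it.

Of the compounds shown here, two sharing one core have been measured in a functional assay, read by spectrophotometry, tested at 100 uM; a lower number here means a stronger inhibitor, a higher number a weaker inhibitor. Compound 1 (`O=C(/C=C/c1ccc(F)cc1)c1cccc(NC(=O)c2cc(-c3ccncc3)n[nH]2)c1`) gives 56000 nM, and compound 2 (`O=C(/C=C/c1cccs1)c1cccc(NC(=O)c2cc(-c3ccncc3)n[nH]2)c1`) gives 27600 nM, the lower of the two numbers. Among the compounds with values here, the one measured step between them is a 2.0-fold lower number from compound 1 to compound 2 (0.31 log units; beyond the scatter), and it is modest. The unmeasured compound 3 (`COc1ccc(/C=C/C(=O)c2cccc(NC(=O)c3cc(-c4ccncc4)n[nH]3)c2)cc1`) carries 4-methoxyphenyl in place of thiophen-2-yl on a double-bonded chain carbon bound to a double-bonded chain carbon. The change falls at the same place as the measured step, and it restores a six-membered aromatic ring of carbon only, as in the 4-fluorophenyl of compound 1. Within the data shown here, no measured compound carries 4-methoxyphenyl, so that single step is the only guide. Among the measured compounds shown here, with compound 1 at 56000 nM as the sole comparison, a modest move toward a higher number is expected in this assay. The estimated size of this move is a 1.7-fold higher number from compound 2 to compound 3 (0.24 log units; within the scatter). In this assay, compound 3 is expected at 48000 nM, with an estimated range from 22000 nM to 100000 nM.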

Compound 3, half-maximal inhibitory concentration: 38400 nM
For compound 3 the middle estimate is 1.3-fold (0.10 log units) above the measured one; measured number inside the range.
By their numbers in this assay, from the lowest: compounds 2, 3 and 1 (each within the scatter of the next, the first and the last beyond it).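

In this assay the exchange of thiophen-2-yl for 4-methoxyphenyl gives a 1.4-fold higher number from compound 2 to compound 3 (0.14 log units; within the scatter) and so does not separate the two groups, although a five-membered aromatic ring with one hetero atom gives way to a six-membered aromatic ring of carbon only. The new compound also adds a comparison within the six-membered ring, where a 1.5-fold lower number from compound 1 to compound 3 (0.16 log units; within the scatter) shows that methoxy in place of fluoro on an aromatic carbon makes no difference beyond the scatter. Compound 3 therefore lies within the scatter of both other compounds, and the only separation beyond it among these three groups remains the modest one between the 4-fluorophenyl and thiophen-2-yl compounds. Nothing on hand accounts for any of these numbers.

The compounds shown leave open whether a group of another kind at this place, such as an amine or a carboxylic acid on the ring or a plain alkyl chain in place of the ring, would move the number further. Also open, as far as these compounds go, is whether changes elsewhere on the shared core would produce larger steps than those seen here.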